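A few compounds are considered here, and "the series" means these few. Any claim that something is new, unique, unknown or untested is made for them only; others in the source may bear on it.

Compound 1 `O=c1ccoc2cc(OCc3cn(Cc4ccc(Cl)cc4)nn3)ccc12`: 37600 nM
Compound 2 `O=c1ccoc2cc(OCc3cn(Cc4ccccc4F)nn3)ccc12`: > 100000 nM (a limit of the assay)

In a functional assay on HeLa cells (Homo sapiens) for cytotoxicity, read by MTT assay, with a stated time of 48 h (a higher number here means a weaker inhibitor, a lower number a stronger inhibitor), compound 1 gives 37600 nM. For compound 2 the reported > 100000 nM is a limit of this assay and not a number (the limit of > 100000 nM in this assay, at which 1 of the 2 values shown sits). Compound 2 thus stands at the weak end of the two values shown, reached by an at least 2.6-fold higher number from compound 1 to compound 2 (0.42 log units; beyond the scatter). Compound 3 `N#Cc1cccc(Cn2cc(COc3ccc4c(=O)ccoc4c3)nn2)c1` carries 3-cyanophenyl in place of 2-fluorophenyl on a saturated chain carbon bound to an aromatic nitrogen. For the measured compounds named here, no measured step alters the group in this way, so the only guide is that compound 2 already sits at the limit. The expected step is a number no higher from compound 2 to compound 3 (the limit leaves the size open), not beyond the scatter. Compound 3 is estimated at 100000 nM, between 35000 nM and 300000 nM.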

Compound 3, half-maximal inhibitory concentration: > 100000 nM
Compound 3 ended at the assay's limit; the forecaster's own chance of this, stated with the estimate: 60%; the middle value sits exactly at the limit.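

In this assay the limit recurs with compound 3, so a second group in place of 4-chlorophenyl on a saturated chain carbon bound to an aromatic nitrogen again gives no number: the limit of > 100000 nM in this assay, at which 2 of the 3 values shown sit. The change to 3-cyanophenyl brings an at least 2.6-fold higher number from compound 1 to compound 3 (0.42 log units; beyond the scatter). The step between the two compounds at the limit cannot be read, so 2-fluorophenyl and 3-cyanophenyl cannot be ordered, and compound 1 remains the only one of the three with a number.

As far as these compounds go, what an amine or a carboxylic acid on the phenyl ring would give here stays open. So does how weak compound 2 and compound 3 really are.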